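The source may report more compounds than this note shows. Statements on the series, on what has been measured and on what is new or still open speak of the compounds shown alone.

Compound 1, `NCC1(O)CCCCCCCCCC1` — in an assay on isolated protein for inhibition of Phenylethanolamine N-methyltransferase (Bos taurus) (a higher number here means a weaker inhibitor, a lower number a stronger inhibitor), compound 1 gives 3560 nM.
Compound 2, `NC[C@@]1(O)CCC2CCCCC2C1` — in this assay compound 2 gives 5630 nM.

Compound 2 carries the higher of the two numbers, yet its gap to compound 1 lies within the scatter, so the two cannot be ranked. Compound 3, `NC[C@]1(O)CCC2CCCCC2C1`, differs from compound 2 only in the drawn configuration: the two compounds have the same atoms and bonds; at least one stereo element is drawn with a configuration in one of them and without one in the other: 1 of 3 stereo elements differ; a stereocentre at a saturated ring carbon is drawn R in compound 2 and S in compound 3. Within the data shown here, no measured pair shows what such an inversion does here, so the direction of the step is open; a change beyond the scatter in either direction is possible. Compound 3 is therefore expected near 4500 nM, within a wide range of 900 nM to 22000 nM, a step of a 1.3-fold lower number from compound 2 to compound 3 (0.10 log units; within the scatter) that is estimated rather than known.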

Compound 3, inhibition constant: 3800 nM
The estimate for compound 3 lay 1.2-fold (0.07 log units) above the measured number, and the stated range covers the measured number.
By their numbers in this assay, from the lowest: compounds 1, 3 and 2 (each within the scatter of the next).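

Inverting this saturated ring carbon from R to S is the first change here that can be read as a direct step, and in this assay it gives a 1.5-fold lower number from compound 2 to compound 3 (0.17 log units; within the scatter), so compounds 2 and 3 cannot be ranked. At this position, the drawn configuration therefore shows no clear preference. This reading carries one caveat: the fact that one of compounds 2 and 3 is drawn with a defined configuration and the other without, at the place where they differ.

Going by these compounds, whether the other stereo elements matter remains open. So does whether a carboxylic acid in place of the amine would move the number beyond the scatter.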